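A few compounds are considered here, and "the series" means these few. Any claim that something is new, unique, unknown or untested is made for them only; others in the source may bear on it.

Three compounds share one core and differ only in the group on an oxygen of the aromatic ring. In an assay on isolated protein for inhibition of Amine oxidase [flavin-containing] B (Homo sapiens), read by Amplex Red (a lower number here means a stronger inhibitor, a higher number a weaker inhibitor), compound 3 `NC/C=C(/F)COc1ccc(OC(F)(F)F)cc1` gives 70 nM, the lowest of the three numbers. Compound 1 `COc1ccc(OC/C(F)=C\CN)cc1` gives 310 nM and compound 2 `NC/C=C(/F)COc1ccc(Oc2ccccc2)cc1` gives 450 nM. The two steps that bear here, a 4.4-fold lower number from compound 1 to compound 3 (0.65 log units; beyond the scatter) and a 6.4-fold lower number from compound 2 to compound 3 (0.81 log units; beyond the scatter), both lowered the number when trifluoromethyl arrived, while a 1.5-fold higher number from compound 1 to compound 2 (0.16 log units; within the scatter) changed little.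

Compound 4 `NC/C=C(/F)COc1ccc(C(N)=O)cc1` differs from compound 3 in one place: carbamoyl in place of trifluoromethoxy on an aromatic carbon. Going by the values given here, no measured step puts a carbamoyl on the ring, so the direction rests on the loss of the trifluoromethoxy that gave compound 3 its low value of 70 nM; the expected step is a 5.7-fold higher number from compound 3 to compound 4 (0.76 log units; beyond the scatter). Compound 4 is therefore estimated at 400 nM, within 120 nM to 1500 nM.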

Compound 4, half-maximal inhibitory concentration: > 30000 nM
Compound 4 ended at the assay's limit; the forecaster's own chance of this, stated with the estimate: 5%; at least 75-fold (1.87 log units) between middle value and limit.
By their numbers in this assay, from the lowest: compound 3; then compounds 1 and 2 (each within the scatter of the next). At a limit, above all of these: compound 4.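

In this assay the value of compound 4, > 30000 nM, is a limit of the assay and not a number. Changes on the oxygen had moved the number only modestly or not beyond the scatter, whereas carbamoyl in place of the oxygen-linked groups on this aromatic carbon gives far larger steps: an at least 420-fold higher number from compound 3 to compound 4 (2.63 log units; beyond the scatter) and an at least 96-fold higher number from compound 1 to compound 4 (1.98 log units; beyond the scatter). This position is therefore far from indifferent to the group it carries.

From the compounds shown here alone, it remains open whether the carbamoyl itself or the loss of the ring oxygen matters more. A nitrile or a carboxylic acid on this carbon, or a methyl amide, could help separate the two.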